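The compounds below may be only part of what the source reports. "The series", "measured", "known", "first", "only" and "open" are said of these compounds alone.

Compound 3, with structure `[SeH]c1nc(NCc2ccccc2)c2ccccc2n1`, is the starting point. In a functional assay on CCRF-CEM cells (Homo sapiens) for cytotoxicity, read by MTT assay, with a stated time of 72 h (a lower number here means that less compound is tolerated, a higher number that more compound is tolerated), compound 3 gives > 100000 nM, which is a limit of the assay and not a number. Compound 1, `COc1ccc(CNc2nc([SeH])nc3ccccc23)cc1`, gives > 100000 nM in this assay, again a limit. Compound 2, `CCCCC[Se]c1nc(NCc2ccccc2)c2ccccc2n1`, gives > 100000 nM, also a limit. Each of these two neighbours differs from compound 3 in a single place, yet the steps a step that the two limits leave unreadable from compound 1 to compound 3 and a step that the two limits leave unreadable from compound 2 to compound 3 cannot be read, since all three values sit at the limit of > 100000 nM in this assay, at which 3 of the 3 values shown sit. Compound 4, `CSc1nc(NCc2ccccc2)c2ccccc2n1`, differs from compound 3 by a group of 2 heavy atoms (1 carbon, 1 sulfur; no ring) in place of one selenium atom, on an aromatic carbon. Among the compounds with values here, with no readable step among the measured compounds, the change to compound 4 in this assay is expected to amount to a number no higher from compound 3 to compound 4 (the limit leaves the size open), and no direction can be drawn from the numbers so far. Given that every measured neighbour sits at the limit, compound 4 is estimated at 100000 nM, within a range from 30000 nM to 300000 nM, and most likely will again be reported only as a limit.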

Compound 4, concentration lethal to 50% of the cells: > 100000 nM
Compound 4 ended at the assay's limit; the forecaster's own chance of this, stated with the estimate: 80%; the middle value sits exactly at the limit.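

The steps from compound 3 and from compound 2 to compound 4 cannot be read, as every value sits at one limit: the limit of > 100000 nM in this assay, at which 4 of the 4 values shown sit.

The compounds shown leave open whether methylsulfanyl in place of selenium changes cytotoxicity at all, as none of them has a value that is an actual number.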